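A few compounds are considered here, and "the series" means these few. Any claim that something is new, unique, unknown or untested is made for them only; others in the source may bear on it.

In a functional assay on MCF7 cells (Homo sapiens) for cytotoxicity, read by resazurin assay, with a stated time of 72 h (a lower number here means a stronger inhibitor, a higher number a weaker inhibitor), compound 1 `Cc1nc2cc(C(=O)N/N=C\c3ccco3)c([N+](=O)[O-])cc2[nH]1` gives 81000 nM. Compound 2 `Cc1nc2cc(C(=O)N/N=C\c3ccccn3)c([N+](=O)[O-])cc2[nH]1` reaches only the limit of the assay, > 100000 nM, so its place on the scale is not a number. Between them lies one measured step, an at least 1.2-fold higher number from compound 1 to compound 2 (0.09 log units; that floor lies within the scatter), whose floor rests on (the limit of > 100000 nM in this assay, at which 1 of the 2 values shown sits). Compound 3 `Cc1nc2cc(C(=O)N/N=C\c3c[nH]c4ccccc34)c([N+](=O)[O-])cc2[nH]1` differs from compound 2 by 1H-indol-3-yl in place of pyridin-2-yl on a carbon with a double bond to nitrogen. Within the data shown here, no measured step covers this change, and the two known values both point to weak inhibition. A modest step of an at least 1.6-fold lower number from compound 2 to compound 3 (0.22 log units; that floor lies within the scatter) is therefore expected. Compound 3 is estimated at 60000 nM, between 15000 nM and 200000 nM.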

Compound 3, half-maximal inhibitory concentration: > 100000 nM
Compound 3: a limit, no number; the forecaster's own chance of this, stated with the estimate: 45%; at least 1.6-fold (0.22 log units) between middle value and limit.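

On the carbon with a double bond to nitrogen, 1H-indol-3-yl, which brings a second aromatic ring and a hydrogen-bond donor, gives no number either in this assay: compound 3 stands at a limit, and the step from compound 2 cannot be read. Set against furan-2-yl, the change gives an at least 1.2-fold higher number from compound 1 to compound 3 (0.09 log units; that floor lies within the scatter). Only compound 1 now has a true number on this scale: the limit of > 100000 nM in this assay, at which 2 of the 3 values shown sit.

Open, as far as these compounds go, is how far past the limit compound 2 and compound 3 lie. Also open, from the compounds shown here alone, is whether a plain phenyl ring or a group carrying an amine or a carboxylic acid at this place would give a clearly lower number.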